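The source may report more compounds than this note shows. Statements on the series, on what has been measured and on what is new or still open speak of the compounds shown alone.

In a functional assay on PC-3 cells (Homo sapiens) for antiproliferative activity, read by MTT assay, with a stated time of 24 h (on this read-out lower numbers stand for stronger inhibition and higher numbers for weaker inhibition), compound 2 `CCn1c(C(=O)N[C@@H](CO)C(C)C)ccc1C(CC)(CC)c1ccc(OCS(=O)(=O)c2ccccc2)c(C)c1` gives 10600 nM and compound 3 `CCn1c(C(=O)N[C@@H](CO)CCO)ccc1C(CC)(CC)c1ccc(OCS(=O)(=O)c2ccccc2)c(C)c1` gives 14100 nM. Among the measured compounds shown here, the gap is a 1.3-fold higher number from compound 2 to compound 3 (0.12 log units; within the scatter), so compound 3 stands level with the only other numeric value in the set. Compound 1 `CCn1c(C(=O)NCC(=O)OC)ccc1C(CC)(CC)c1ccc(OCS(=O)(=O)c2ccccc2)c(C)c1` gives > 50000 nM, which is a limit of the assay and not a number.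

The next comparison is with compound 4 `CCn1c(C(=O)NCC(=O)O)ccc1C(CC)(CC)c1ccc(OCS(=O)(=O)c2ccccc2)c(C)c1`, which carries carboxymethyl in place of 3-hydroxy-1-(hydroxymethyl)propyl on an amide-type nitrogen. For the measured compounds named here, no measured compound has carboxymethyl itself, so the closest guide is the (methoxycarbonyl)methyl group of compound 1. Two measured steps at the same place bear on this: an at least 3.5-fold lower number from compound 1 to compound 3 (0.54 log units; beyond the scatter) and an at least 4.7-fold lower number from compound 1 to compound 2 (0.67 log units; beyond the scatter). Going by these compounds, both are bounded by the limit, so their full size is unknown. Read in reverse, they point towards weaker inhibition on leaving the hydroxylated chain, by at least a modest amount.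

The expected change is a 3.2-fold higher number from compound 3 to compound 4 (0.50 log units; beyond the scatter), in the direction of a higher number in this assay. Compound 4 may well be reported only as a limit. For compound 4 the estimated value is 45000 nM, with an expected range from 15000 nM to 120000 nM.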

Compound 4, half-maximal inhibitory concentration: 30100 nM
The estimate for compound 4 lay 1.5-fold (0.17 log units) above the measured number; the range from low to high includes it.
By their numbers in this assay, from the lowest: compounds 2 and 3 (each within the scatter of the next); then compound 4. At a limit, above all of these: compound 1.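

In this assay, among the compounds shown here, moving from the hydroxylated chains to carboxymethyl on the amide-type nitrogen gives the first step at this position with numbers at both ends: a 2.1-fold higher number from compound 3 to compound 4 (0.33 log units; beyond the scatter) and a 2.8-fold higher number from compound 2 to compound 4 (0.45 log units; beyond the scatter). Both steps are modest, and compounds 2 and 3 stand level, so the two hydroxylated chains sit together with carboxymethyl apart from them; the change also removes a defined stereocentre and shortens the group, and these pairs cannot separate those differences. Hydrogen in place of methyl on an oxygen next to a carbonyl group gives an at least 1.6-fold lower number from compound 1 to compound 4 (0.22 log units; that floor lies within the scatter), so the floor of this step cannot be told from the scatter, and its full size stays unread, with compound 1 remaining a limit and not a number: the limit of > 50000 nM in this assay, at which 1 of the 4 values shown sits.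

Still open, going by these compounds, is whether an amine, a primary amide or a longer chain ending in a carboxylic acid on the amide-type nitrogen would read like carboxymethyl or like the hydroxylated chains. The shared core is also constant throughout, so these compounds do not tell whether the steps would hold on a different core.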